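Lengthening the Ether Side Chain: From Compound 3 to Compound 4

A few compounds are considered here, and "the series" means these few. Any claim that something is new, unique, unknown or untested is made for them only; others in the source may bear on it.

Measured in an assay on HEK293 cells for agonist activity at putative P2Y purinoceptor 10 (Mus musculus), with a stated time of 1 h; on this read-out higher numbers stand for larger maximal responses and lower numbers for smaller maximal responses:
- compound 1, `CCCCCCCC/C=C\CCCCCCCC(=O)OC[C@@H](C)OP(=O)(O)OC[C@H](N)C(=O)O`: 12.4%
- compound 2, `CCCCCCCC/C=C\CCCCCCCC(=O)OC[C@H](COC)OP(=O)(O)OC[C@H](N)C(=O)O`: "not active" (no number reported)
- compound 3, `CCCCCCCC/C=C\CCCCCCCC(=O)OC[C@@H](COCC)OP(=O)(O)OC[C@H](N)C(=O)O`: "not active" (no number reported)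

Three compounds share one core and differ only in the group on the carbon that carries the phosphate. In this assay compound 1, which carries a methyl there, gives 12.4%, a small response. Compound 2 carries a methoxymethyl group and is reported as "not active" (no number reported), with no number attached. Compound 3 carries an ethoxymethyl group and is likewise reported as "not active" (no number reported); so compound 3 stands among the entries for which no number exists at all, and nothing separates it from compound 2 on the figures available.

Compound 4, `CCCCCCCC/C=C\CCCCCCCC(=O)OC[C@@H](COCCC)OP(=O)(O)OC[C@H](N)C(=O)O`, continues the ether series. Its change from compound 3 is methyl in place of hydrogen on a saturated chain carbon, two bonds along the chain from an oxygen on a saturated carbon. The two ether compounds already measured show no response that was worth a number, and nothing in the figures gives a reason to expect compound 4 to break from that. The expectation for compound 4 in this assay is therefore a response at or near the bottom of the scale, most likely again without a reported number.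

The expected value for compound 4 is 5%, within a range from 0% to 15%.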

Compound 4, largest response reached (Emax), in percent of the reference or control that the assay uses: "not active" (no number reported)
Nothing numeric was reported for compound 4, so the estimate cannot be set against anything.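

Compound 3 and compound 4 are both reported as not active, without a number, and no step can be read between them. No other data bear on this result. The compounds shown leave open whether any ether side chain on the shared core can give a measurable response in this assay at all.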